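From 1,3-thiazol-4-yl to 1,2,4-oxadiazol-3-yl in compound 3

A few compounds are considered here, and "the series" means these few. Any claim that something is new, unique, unknown or untested is made for them only; others in the source may bear on it.

Among the compounds with values here, in an ADME assay on the whole organism (plasma, strain 129/SvEvBrd x C57BL/6) for pharmacokinetics, with Mus musculus as the target, at a dose of 10 mg/kg by the oral route (a higher number here means more compound in the circulation at the dose given, a lower number less compound in the circulation), compound 1 (`CC(=O)c1cccc([C@@H](O)[C@H](O)[C@H](O)CO)n1`) gives 10500 ng.h/mL as the higher of two numbers so far. Compound 2 (`OC[C@@H](O)[C@@H](O)[C@H](O)c1c[nH]c(-c2cscn2)n1`) gives 1570 ng.h/mL as the lower number, and its gap to compound 1 lies beyond the scatter. These two structures differ in more than one place, so the gap cannot be tied to any single change. Compound 3 (`OC[C@@H](O)[C@@H](O)[C@H](O)c1c[nH]c(-c2ncon2)n1`) keeps the core of compound 2 and has 1,2,4-oxadiazol-3-yl in place of 1,3-thiazol-4-yl on an aromatic carbon between two ring nitrogen atoms (1,2,4-oxadiazol-3-yl in place of 1,3-thiazol-4-yl on an aromatic carbon). Within the data shown here, no measured pair covers this exchange, so no step beyond the scatter is expected in this assay and no direction is favoured. The estimated change a 1.1-fold higher number from compound 2 to compound 3 (0.06 log units; within the scatter) is expected to stay within the scatter. For compound 3 the estimate is 1800 ng.h/mL with an expected range from 500 ng.h/mL to 6000 ng.h/mL in this read-out.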

Compound 3, area under the concentration-time curve: 820 ng.h/mL
Estimate against measurement, compound 3: 2.2-fold (0.34 log units) above; low and high end bracket the measured number.
By their numbers in this assay, from the lowest: compounds 3 and 2 (each within the scatter of the next); then compound 1.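

In this assay, 1,2,4-oxadiazol-3-yl in place of 1,3-thiazol-4-yl on an aromatic carbon between two ring nitrogen atoms gives a 1.9-fold lower number from compound 2 to compound 3 (0.28 log units; within the scatter). This first single-place comparison in the series shows that, for this pair, one five-membered aromatic ring can replace the other at this position without a step beyond the scatter. The change from 2 to 3 ring hetero atoms, with 5 heavy atoms on each side, therefore leaves no readable difference in this read-out. No measurement at hand bears on the cause of the values.

On these data alone, whether an amine or a carboxylic acid on this aromatic carbon would give a step beyond the scatter remains open. As far as these compounds go, compound 1 at 10500 ng.h/mL differs from compound 2 and compound 3 in more than one place, so the structural source of its separation from them also remains open.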